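The compounds below may be only part of what the source reports. "The series", "measured", "known", "first", "only" and "open" are said of these compounds alone.

The measured compounds:
Compound 1, `O=C(Nc1cc(Sc2ncn[nH]2)c(O)c2ccccc12)c1cccc([N+](=O)[O-])c1`, in a functional assay on MDA-MB-231 cells (Homo sapiens) for antiproliferative activity, read by MTT assay, with a stated time of 48 h (a higher number here means a weaker inhibitor, a lower number a stronger inhibitor), gives 48000 nM.
Compound 2, `O=C(/C=C/c1ccccc1)Nc1cc(Sc2ncn[nH]2)c(O)c2ccccc12`, in this assay reaches only a limit, > 100000 nM.
Compound 3, `COc1cccc(C(=O)Nc2cc(Sc3ncn[nH]3)c(O)c3ccccc23)c1`, in this assay likewise reaches only a limit, > 100000 nM.

Compound 3 therefore stands at the edge of what this assay reports, and two of the three values shown sit at that same boundary (the limit of > 100000 nM in this assay, at which 2 of the 3 values shown sit). Compound 4, `Cc1cccc(C(=O)Nc2cc(Sc3ncn[nH]3)c(O)c3ccccc23)c1`, is the one that remains to be measured; it differs from compound 3 by methyl in place of methoxy on an aromatic carbon.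

Within the data shown here, two measured steps touch this change. The replacement on the same aromatic carbon, nitro to methoxy, gave an at least 2.0-fold higher number from compound 1 to compound 3 (0.31 log units; beyond the scatter). The exchange of the whole acyl part, a step that the two limits leave unreadable from compound 2 to compound 3, lies between two limits and says nothing about direction. Among the measured compounds shown here, no measured step involves a methyl at that position, so the nearest guide is that a small neutral group at this carbon has so far left the compound at the limit.

Compound 4 is therefore expected to give about 100000 nM in this assay, with a range from 40000 nM to 250000 nM. This estimate means an expected step of a number no higher from compound 3 to compound 4 (the limit leaves the size open), that is, no change beyond the scatter, with a good chance that only a limit is reported again.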

Compound 4, half-maximal inhibitory concentration: > 100000 nM
Compound 4: no number, only a limit (the forecaster's own chance of this, stated with the estimate: 65%); the middle value sits exactly at the limit.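

In this assay, replacing the nitro group on this aromatic carbon with methyl gives an at least 2.0-fold higher number from compound 1 to compound 4 (0.31 log units; beyond the scatter), so methyl now joins methoxy as a second replacement of nitro that carries a step beyond the scatter, and among compounds 1, 3 and 4 only the nitro compound gives a number rather than a limit. The change from methoxy to methyl itself gives no readable result, and neither does the comparison of compound 4 with compound 2, since both ends of each step are limits. The values shown now gather even more tightly at one boundary: the limit of > 100000 nM in this assay, at which 3 of the 4 values shown sit.

The compounds shown leave open how far compounds 2, 3 and 4 lie beyond that limit, so no order can be given among them, and methyl and methoxy cannot be told apart at this carbon. Among these compounds, they also leave open whether nitro is the only group here that brings a compound back within the reported range, or whether a nitrile, an amine or a carboxylic acid on the same carbon would also give a number.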